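Adding a methoxy group to a nitrile-bearing compound

The source may report more compounds than this note shows. Statements on the series, on what has been measured and on what is new or still open speak of the compounds shown alone.

Compound 1 `COc1cccc(-c2nc3ncccc3o2)c1` gives 14% in a functional assay on the whole organism for inhibition, with Rattus norvegicus as the target, at a dose of 30 mg/kg; a lower number here means less inhibition, a higher number more inhibition at the dose given (going by the name of the read-out).
Compound 2 `N#Cc1ccccc1-c1nc2ncccc2o1` gives 62% in this assay.

Of these two measured compounds, compound 2 stands highest in this assay, and compound 1 sits a long way below it, well beyond the usual scatter of such measurements. Compound 3 `COc1ccc(C#N)c(-c2nc3ncccc3o2)c1` has not yet been measured. It differs from compound 2 in one place only: methoxy in place of hydrogen on an aromatic carbon. Within the data shown here, no measured pair shows this particular change on its own, so its effect in this assay is unknown from the data at hand. Compound 1 carries a methoxy group but no cyano group, and it gives 14%, so a methoxy group alone is no guarantee of a high number. Compound 3 keeps the cyano group of compound 2, and the expected result is a small downward step, a number 10 percentage points lower from compound 2 to compound 3 (within the scatter), roughly within the scatter. Compound 3 is estimated to give 52%, with a likely range from 25% to 75%.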

Compound 3, a percentage reported as inhibition, in the whole organism at one dose (the size of the read-out at that dose, not a potency): 3%
The estimate for compound 3 lay 49 percentage points above the measured number; measured number outside the range, below it.
By their numbers in this assay, from the lowest: compound 3; then compound 1; then compound 2.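

In this assay, methoxy in place of hydrogen on this aromatic carbon, para to the cyano group, gives a number 59 percentage points lower from compound 2 to compound 3 (beyond the scatter), so this single change removes nearly all of the inhibition seen with compound 2. Keeping the cyano group is therefore no safeguard at this dose. Read from the other side, cyano in place of hydrogen gives a number 11 percentage points lower from compound 1 to compound 3 (beyond the scatter), so with the methoxy group present, adding the cyano group brings no gain and a modest loss.

Nothing measured here gives a reason for either drop. From the compounds shown here alone, whether a hydroxyl group, an amine or a longer chain such as ethoxy on this same carbon would give the same loss stays open, and so does the effect of moving the methoxy group elsewhere on the ring.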